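Adding acetyl to the free amino group of compound 2

This account rests on a few compounds, and the source may have more. Where it says the series, first, only, none or still open, it means among the compounds named here.

In a functional assay on cells (Homo sapiens) for inhibition, read by MTT assay, with a stated time of 72 h (a lower number here means a stronger inhibitor, a higher number a weaker inhibitor), compound 1 `CCOC(=O)Cn1ncc2c(Nc3ccc(NS(=O)(=O)c4ccccc4)cc3)ncnc21` gives only a limit of > 100 ug/mL and no number. Compound 2 `CCOC(=O)Cn1ncc2c(Nc3ccc(N)cc3)ncnc21` likewise gives only the limit > 64 ug/mL and no number. Within the data shown here, the one measured step that the two limits leave unreadable from compound 1 to compound 2 therefore offers no size to carry forward. Compound 3 `CCOC(=O)Cn1ncc2c(Nc3ccc(NC(C)=O)cc3)ncnc21` has acetyl in place of hydrogen on a nitrogen on an aromatic ring with the rest unchanged. The expected step that the limit leaves unreadable from compound 2 to compound 3 is thus no more than a weak guess, with no direction claimed. In this assay compound 3 is estimated at 100 ug/mL within a range from 40 ug/mL to 200 ug/mL and may well return only a limit.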

Compound 3, half-maximal inhibitory concentration: > 64 ug/mL
Compound 3: only a limit was reported; the forecaster's own chance of this, stated with the estimate: 75%; the middle value does not contradict the limit.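

In this assay, among these compounds, compound 1, compound 2 and compound 3 all give only limits, so no step between them can be read. The compounds shown leave open whether phenylsulfonyl, acetyl or hydrogen on this nitrogen differ in inhibition at all.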